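The compounds below may be only part of what the source reports. "The series", "measured", "known", "first", "only" and "open" are said of these compounds alone.

Of the compounds shown here, two of one shared core have been tested so far. Compound 1 `CC(C)(C)OC(=O)C(=O)Nc1cccccc1=O` carries a tert-butyl on an oxygen next to a carbonyl group, and compound 2 `O=C(O)COC(=O)C(=O)Nc1cccccc1=O` carries a carboxymethyl in that place. In a functional assay on the whole organism (strain Sprague-Dawley CD) for inhibition, with Rattus norvegicus as the target, read by paw edema, at a dose of 30 mg/kg by the oral route (on this read-out higher numbers stand for a stronger effect at the one dose given and lower numbers for a weaker effect), compound 1 gives 47%, and compound 2 gives 45%. Among the compounds with values here, the only step measured, a number 2 percentage points lower from compound 1 to compound 2 (within the scatter), shows that exchanging these two groups left the read-out essentially unchanged. On the numbers shown, compound 2 therefore stands side by side with compound 1, its only neighbour, within the scatter.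

Compound 3 `O=C(Nc1cccccc1=O)C(=O)Oc1ccccc1` has not yet been tested. It differs from compound 2 as follows: phenyl in place of carboxymethyl on an oxygen next to a carbonyl group. Within the data shown here, the one measured step that bears on this change sits at the same oxygen and was within the scatter, so no step beyond the scatter is expected in this assay. For compound 3 the estimate is 46%, expected between 30% and 62%, meaning an expected step of a number 1 percentage points higher from compound 2 to compound 3 (within the scatter).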

Compound 3, a percentage reported as inhibition, in the whole organism at one dose (the size of the read-out at that dose, not a potency): 31%
Compound 3: the middle estimate sits 15 percentage points above what was measured; low and high end bracket the measured number.
By their numbers in this assay, from the lowest: compound 3; then compounds 2 and 1 (each within the scatter of the next).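

Phenyl in place of carboxymethyl gives a number 14 percentage points lower from compound 2 to compound 3 (beyond the scatter) and phenyl in place of tert-butyl gives a number 16 percentage points lower from compound 1 to compound 3 (beyond the scatter) in this assay so the group on an oxygen next to a carbonyl group can matter for this read-out, which the first exchange did not reveal. Phenyl is also the only one of the three groups with an aromatic ring, and it is the only one that stands apart from the other two, although three compounds cannot show that the ring itself is what counts. Nothing available explains this drop.

From the compounds shown here alone, whether any aromatic ring here gives the same result, or only this plain phenyl, remains open. A benzyl group or a methoxyphenyl on that oxygen would test this, while a methyl or a longer chain would show how small or long an open-chain group can be.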